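A few compounds are considered here, and "the series" means these few. Any claim that something is new, unique, unknown or untested is made for them only; others in the source may bear on it.

Measured compounds:
- compound 1 `NS(=O)(=O)c1ccc(NC(=O)NCc2ccncc2)cc1` — 14300 nM
- compound 2 `CCOC(=O)c1ccc(NC(=O)NCc2cn[nH]c2)cc1` — 1850 nM

In an assay on isolated protein for activation of Nicotinamide phosphoribosyltransferase (Homo sapiens) (on this read-out higher numbers stand for an effect only at larger amounts of compound and lower numbers for an effect already at smaller amounts), compound 1 gives 14300 nM, the higher of the two numbers; compound 2 gives 1850 nM, a gap beyond the scatter. Compound 3 `O=C(NCc1ccncc1)Nc1ccc(S(=O)(=O)c2cccc(Cl)c2)cc1` is not yet measured. It differs from compound 1 by 3-chlorophenyl in place of amino on a sulfonyl sulfur. Among the compounds with values here, no measured pair shows this change, so its size is uncertain; the expectation is a move toward lower numbers, a 4.8-fold lower number from compound 1 to compound 3 (0.68 log units; beyond the scatter), since compound 1 starts from 14300 nM. Compound 3 is estimated at 3000 nM, within 800 nM to 15000 nM.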

Compound 3, half-maximal effective concentration: 69 nM
Compound 3: middle estimate off by 43-fold (1.64 log units), on the high side; measured number outside the range, below it.
By their numbers in this assay, from the lowest: compound 3; then compound 2; then compound 1.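

In this assay, 3-chlorophenyl in place of amino on a sulfonyl sulfur brings a 210-fold lower number from compound 1 to compound 3 (2.32 log units; beyond the scatter), so this position strongly governs the read-out. The amino group and its hydrogen-bond donor are not needed for an effect at small amounts of compound. Nothing available gives a reason for the size of this step.

From the compounds shown here alone, whether the ring or its chlorine carries the change stays open. Plain phenyl, or methyl on the same sulfur, would separate the two.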